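A few compounds are considered here, and "the series" means these few. Any claim that something is new, unique, unknown or untested is made for them only; others in the source may bear on it.

Three compounds have been measured in an assay on isolated protein for displacement of a labelled ligand from metabotropic glutamate receptor 5 (Homo sapiens), with a stated time of 60 min, tested at 1 uM; a higher number here means more inhibition at the concentration tested (going by the name of the read-out), a lower number less inhibition:

Compound 1 `CC1CCN(c2c(S(=O)(=O)c3ccc(Cl)c(Cl)c3)cnc3cc(F)ccc23)CC1` gives 94%.
Compound 2 `CC1CCN(c2c(S(=O)(=O)c3cc(Cl)cc(Cl)c3)cnc3cc(F)ccc23)CC1` gives 87%.
Compound 3 `CC1CCN(c2c(S(=O)(=O)c3cc(Cl)cc(Cl)c3)cnc3c(F)cccc23)CC1` gives 82%.

Compound 1 and compound 2 share a core and differ only in the group on the sulfonyl sulfur: 3,4-dichlorophenyl in place of 3,5-dichlorophenyl on a sulfonyl sulfur. That change made a number 7 percentage points higher from compound 2 to compound 1 (within the scatter). Compound 3 carries a different core from compound 2; the difference between the two cores is not broken down here. In this assay compound 3 stands nearest to compound 2, within the scatter, and furthest from compound 1, beyond the scatter.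

Compound 4 `CC1CCN(c2c(S(=O)(=O)c3ccc(Cl)c(Cl)c3)cnc3c(F)cccc23)CC1` has not yet been measured. It relates to compound 3 as compound 1 relates to compound 2, by the same change: 3,4-dichlorophenyl in place of 3,5-dichlorophenyl on a sulfonyl sulfur. Because the change from compound 2 to compound 1 gave a number 7 percentage points higher from compound 2 to compound 1 (within the scatter), a step of similar size, a number 6 percentage points higher from compound 3 to compound 4 (within the scatter), is expected from compound 3 to compound 4, though a single earlier instance gives only modest support. On that basis compound 4 is estimated to give 88%, with a likely range from 78% to 96%.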

Compound 4, a percentage reported as inhibition, at one concentration (the size of the read-out at that concentration, not a potency): 95%
Compound 4: middle estimate off by 7 percentage points, on the low side, within the range that was stated.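

In this assay, 3,4-dichlorophenyl in place of 3,5-dichlorophenyl on the sulfonyl sulfur gave a number 13 percentage points higher from compound 3 to compound 4 (beyond the scatter), so the change carried over to a second core in the same direction. The size of the step cannot be said to depend on the core, since the two steps do not differ by more than the scatter allows: the same change on two cores in this assay, a number 7 percentage points higher (within the scatter) from compound 2 to compound 1 and a number 13 percentage points higher (beyond the scatter) from compound 3 to compound 4, 6 percentage points apart, within the scatter of two such steps

Two pairs show only that the direction held on these two cores; they do not show that it would hold on a third core, nor that the change is worth more on one core than on the other.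

As far as these compounds go, what stays open is whether the step would persist with other groups on the sulfonyl sulfur, such as a methoxyphenyl, a pyridine or a short alkyl chain, or on a core that carries no fluorine. Also open, from the compounds shown here alone, is how the compounds would compare as full potencies, since each reading comes from a single concentration.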